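The compounds below may be only part of what the source reports. "The series", "measured", "known", "first", "only" and "open" are said of these compounds alone.

Measured in an assay on HeLa cells for displacement of a labelled ligand from 5-hydroxytryptamine receptor 6 (Homo sapiens); a higher number here means a weaker inhibitor, a lower number a stronger inhibitor:
compound 1 `O=S(=O)(c1ccc(Cl)cc1)c1n[nH]c2cc(N3CCNCC3)ccc12`: 110 nM
compound 2 `COc1ccc(S(=O)(=O)c2n[nH]c3cc(N4CCNCC4)ccc23)cc1`: 124 nM
compound 3 `COc1ccc(S(=O)(=O)c2n[nH]c3ccc(N4CCN(C)CC4)cc23)cc1`: 12 nM

Compound 1 and compound 2 share a core and differ only by chloro in place of methoxy on an aromatic carbon; the step of a 1.1-fold lower number from compound 2 to compound 1 (0.05 log units; within the scatter) is flat. Compound 3 stands well apart, its nearest neighbour being compound 1; how the core of compound 3 differs from that of compound 2 is not broken down here.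

Compound 4 `CN1CCN(c2ccc3[nH]nc(S(=O)(=O)c4ccc(Cl)cc4)c3c2)CC1` is not yet measured. It differs from compound 3 by chloro in place of methoxy on an aromatic carbon, the same change that runs from compound 2 to compound 1, at a place described in the same words. Among the measured compounds shown here, since that earlier step stayed within the scatter, the step from compound 3 to compound 4 is expected to be about as small, a 1.1-fold lower number from compound 3 to compound 4 (0.04 log units; within the scatter), resting on the single precedent a 1.1-fold lower number from compound 2 to compound 1 (0.05 log units; within the scatter). Compound 4 is therefore estimated at 11 nM in this assay, with a plausible range from 5 nM to 26 nM.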

Compound 4, inhibition constant: 8.1 nM
For compound 4 the middle estimate is 1.4-fold (0.13 log units) above the measured one; the measured number falls inside the stated range.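

In this assay, the change from 4-methoxyphenyl to 4-chlorophenyl gives a 1.5-fold lower number from compound 3 to compound 4 (0.17 log units; within the scatter), so it remains a small step on this second core. The two cores agree on this change: the same change on two cores in this assay, a 1.1-fold lower number (0.05 log units; within the scatter) from compound 2 to compound 1 and a 1.5-fold lower number (0.17 log units; within the scatter) from compound 3 to compound 4, 1.3-fold (0.12 log units) apart, within the scatter of two such steps. Among the compounds shown here, this shows that the swap carried over between these two cores, but with only one pair per core and only these two groups, it does not show that it would hold on other cores or for other replacements.

Left open is how a different group on that aromatic carbon, such as an amine, a carboxylic acid or a nitrile, would behave in this assay. Also open, on these data alone, is which feature of the core of compound 3, set against that of compound 2, goes with its lower number.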